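This account rests on a few compounds, and the source may have more. Where it says the series, first, only, none or still open, it means among the compounds named here.

Measured set:
compound 1 `Cc1ccc(C2=NN(c3nc(-c4ccccc4)c(C#N)c(=O)n3C)C(c3ccc(F)cc3)C2)cc1` — 23100 nM
compound 2 `Cn1c(N2N=C(c3ccccc3)CC2c2ccc(Cl)cc2)nc(-c2ccc(Cl)cc2)c(C#N)c1=O` — 46300 nM
compound 3 `Cn1c(N2N=C(c3ccccc3)CC2c2ccc(F)cc2)nc(-c2ccc(Cl)cc2)c(C#N)c1=O` — 36800 nM

All three values come from a functional assay on MCF7 cells (Homo sapiens) for antiproliferative activity, with a stated time of 72 h; a higher number here means a weaker inhibitor, a lower number a stronger inhibitor. Compound 3 stands second highest of the three numbers; its nearest neighbour is compound 2, a 1.3-fold lower number from compound 2 to compound 3 (0.10 log units; within the scatter), and its furthest is compound 1, whose number also sits within the scatter of compound 3. The three numbers do not separate from one another.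

Compound 4 `Cc1ccc(C2=NN(c3nc(-c4ccc(Cl)cc4)c(C#N)c(=O)n3C)C(c3ccc(F)cc3)C2)cc1` is not yet measured. It differs from compound 3 in one place: methyl in place of hydrogen on an aromatic carbon. Among the measured compounds shown here, no measured step covers this change. For the measured compounds named here, the single measured step, a 1.3-fold lower number from compound 2 to compound 3 (0.10 log units; within the scatter), concerns a halogen exchange on a different ring and says nothing about the methyl. Compound 1 carries the same 4-methylphenyl as compound 4, but it also differs from compound 3 at a second ring, so the values of compound 1 and compound 3 can only be taken as two numbers within the scatter of each other.

With nothing in the set pointing to a shift, compound 4 is expected to stay close to compound 3, the expected step being a 1.2-fold lower number from compound 3 to compound 4 (0.06 log units; within the scatter) in this assay, none beyond the scatter. For compound 4 the estimated value is 32000 nM, with a range from 15000 nM to 70000 nM.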

Compound 4, half-maximal inhibitory concentration: 116000 nM
Estimate against measurement, compound 4: 3.6-fold (0.56 log units) below, outside the stated range (above it).
By their numbers in this assay, from the lowest: compounds 1, 3 and 2 (each within the scatter of the next); then compound 4.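

In this assay, among the compounds shown here, the change from phenyl to 4-methylphenyl, para to a large group, gives the first one-place step that lies beyond the scatter (a 3.2-fold higher number from compound 3 to compound 4 (0.50 log units; beyond the scatter)), whereas the halogen exchange on the other ring stayed within it. The chloro change on the ring that carries the nitrile-bearing core reaches the same compound and is also beyond the scatter (a 5.0-fold higher number from compound 1 to compound 4 (0.70 log units; beyond the scatter)), so compound 4, which holds both the methyl and this chloro, stands apart from both of these one-place neighbours. No measurement in hand bears on the reason for this rise.

The compounds shown contain no one-place pair that isolates the methyl on a ring without this chloro, so it stays open whether the methyl step depends on the chloro or would appear without it. As far as these compounds go, it is also open whether the rise belongs to methyl alone or extends to other groups at this place, such as methoxy, an amine, a carboxylic acid or a longer chain.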